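This account rests on a few compounds, and the source may have more. Where it says the series, first, only, none or still open, it means among the compounds named here.

Measured so far in a functional assay on MT4 cells (Homo sapiens) for cytotoxicity; on this read-out higher numbers stand for lower toxicity in this test and lower numbers for higher toxicity in this test:
- Compound 1 `CC(C)Sc1nc(Cc2c(F)cccc2F)cc(=O)[nH]1`: > 200000 nM, a limit.
- Compound 2 `CC(c1cc(O)nc(SC2CCCC2)n1)c1cccc2ccccc12`: 93000 nM.
- Compound 3 `CCC(c1cc(O)nc(SC2CCCC2)n1)c1cccc2ccccc12`: > 200000 nM, a limit.

Compound 3 stands at the limit of > 200000 nM in this assay, at which 2 of the 3 values shown sit. It therefore gives no number from which to measure a step.

The next compound is compound 4 `CCC(c1cc(O)nc(SC2CCCCC2)n1)c1cccc2ccccc12`, which carries cyclohexyl in place of cyclopentyl on a sulfur.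

Within the data shown here, no measured step changes the group on the sulfur. Among the measured compounds shown here, the one measured step, an at least 2.1-fold higher number from compound 2 to compound 3 (0.33 log units; beyond the scatter), changes a saturated chain carbon instead, so it bears on the new change only loosely. It does show that a single small change can move the read-out by a modest amount in this series.

For the measured compounds named here, compound 2 gives 93000 nM, the only value here that is a number, so the lower end of the expected range is set close to it.

In this assay, no step beyond the scatter is expected, and any movement that does appear is expected toward lower numbers. The expected step is an at least 1.1-fold lower number from compound 3 to compound 4 (0.04 log units; that floor lies within the scatter), read against a limit and not against a number.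

Compound 4 is estimated at 180000 nM, with an expected range of 80000 nM to 400000 nM.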

Compound 4, half-maximal cytotoxic concentration: 23400 nM
For compound 4 the middle estimate is 7.7-fold (0.89 log units) above the measured one, and the stated range ends above it.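

Among these compounds, until now the only measured change sat on a saturated chain carbon; this is the first measured change in the group on the sulfur, and in this assay cyclohexyl in place of cyclopentyl gives an at least 8.5-fold lower number from compound 3 to compound 4 (0.93 log units; beyond the scatter). The value of compound 3 is > 200000 nM, a limit. The step therefore shows that this position can move the read-out toward higher toxicity in this test, but it fixes only a floor for the size of that move and not the size itself: the limit of > 200000 nM in this assay, at which 2 of the 4 values shown sit.

A single pair cannot show whether the shift follows the added ring carbon or is particular to cyclohexyl, and a cycloheptyl, a phenyl or an open chain such as n-butyl on the sulfur would help separate these readings, as would a polar group such as an amine or a carboxylic acid in the same place. As far as these compounds go, it also remains open whether the same exchange on the sulfur gives a step of similar size and direction when the chain carbon carries the group found in compound 2.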